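Swapping 2-acetylphenyl for 3-methoxyphenyl

This account rests on a few compounds, and the source may have more. Where it says the series, first, only, none or still open, it means among the compounds named here.

Among the compounds with values here, in a functional assay on MCF7 cells (Homo sapiens) for cytotoxicity, read by MTT assay, with a stated time of 48 h (a lower number here means a stronger inhibitor, a higher number a weaker inhibitor), compound 2 `C=C1CCC[C@]2(C)CCC(c3cn(-c4ccccc4C(C)=O)nn3)=CC[C@@]12C` gives 29900 nM, the lower of the two numbers measured so far, while compound 1 `C=C1CCC[C@]2(C)CCC(c3cn(-c4ccc(OC)cc4)nn3)=CC[C@@]12C` gives 118000 nM. These two compounds share one core and differ only in the aromatic group on a nitrogen. Compound 3 `C=C1CCC[C@]2(C)CCC(c3cn(-c4cccc(OC)c4)nn3)=CC[C@@]12C` keeps that core as well, and its difference from compound 2 is 3-methoxyphenyl in place of 2-acetylphenyl on an aromatic nitrogen. Within the data shown here, only one measured step bears on this change. It is a 3.9-fold lower number from compound 1 to compound 2 (0.60 log units; beyond the scatter), a modest step that came with 2-acetylphenyl in place of 4-methoxyphenyl. Among the measured compounds shown here, compound 1, the only measured compound with a methoxyphenyl group, stands at 118000 nM, so a higher number than that of compound 2 is expected. For the measured compounds named here, no measured compound carries 3-methoxyphenyl, which leaves the size uncertain. In this assay the expected change is somewhat smaller than the measured step, estimated as a 2.2-fold higher number from compound 2 to compound 3 (0.34 log units; beyond the scatter). For compound 3 the estimated value is 65000 nM, with an expected range from 22000 nM to 190000 nM.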

Compound 3, half-maximal inhibitory concentration: 56200 nM
Compound 3: the middle estimate sits 1.2-fold (0.06 log units) above what was measured; low and high end bracket the measured number.
By their numbers in this assay, from the lowest: compounds 2 and 3 (each within the scatter of the next); then compound 1.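

In this assay, the step of a 2.1-fold lower number from compound 1 to compound 3 (0.32 log units; beyond the scatter) keeps the methoxy group on the phenyl ring and changes only where it sits, so the place of this one group is enough to shift the number by a modest amount. The other step, a 1.9-fold higher number from compound 2 to compound 3 (0.27 log units; within the scatter), lies within the scatter, so 3-methoxyphenyl and 2-acetylphenyl cannot be told apart in this assay. An acetyl group is therefore not required to reach this level, and among these three compounds the group that stands apart is 4-methoxyphenyl, with compound 1 giving a higher number than both of the others by more than the scatter.

From the compounds shown here alone, whether an amine, a carboxylic acid or a longer chain on the phenyl ring, in place of methoxy or acetyl, would bring the number clearly lower than in compound 2 and compound 3 stays open. Nothing shown here gives a measured account of how the place of the methoxy group bears on the effect on these cells.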